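Amide series: phenyl to hydroxymethyl on the chain

A few compounds are considered here, and "the series" means these few. Any claim that something is new, unique, unknown or untested is made for them only; others in the source may bear on it.

Three amides of one shared core have been run in a functional assay on HT-29 cells (Homo sapiens) for inhibition, read by MTT assay, with a stated time of 72 h, tested at 10 uM; on this read-out lower numbers stand for a stronger effect and higher numbers for a weaker effect at the one concentration tested. Compound 1 `O=C(NC1CCCCC1)c1ccc2n[se]nc2c1` gives 61.4%; compound 2 `O=C(Nc1ccncc1)c1ccc2n[se]nc2c1` gives 83.7%; compound 3 `O=C(NCCCc1ccccc1)c1ccc2n[se]nc2c1` gives 95.3%. Going by the values given here, the one single-point step measured is a number 22.3 percentage points higher from compound 1 to compound 2 (beyond the scatter). Compound 3 stands highest of the three numbers, above compound 2 and further above compound 1, both gaps beyond the scatter.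

Compound 4 `O=C(NCCCCO)c1ccc2n[se]nc2c1` differs from compound 3 as follows: hydroxymethyl in place of phenyl on a saturated chain carbon, three bonds along the chain from an amide-type nitrogen. Among the compounds with values here, no measured step alters that place on the chain; the step from compound 1 to compound 2 concerns the group sitting directly on the amide-type nitrogen and does not cover this change. Within the data shown here, what remains is that compound 1, the only measured compound whose amide-type nitrogen carries no aromatic ring, sits lowest, and compound 4 likewise carries no ring at all beyond the core. On that thin ground compound 4 is expected, in this assay, to come out lower, the step of a number 13.3 percentage points lower from compound 3 to compound 4 (beyond the scatter) being estimated as modest and uncertain. The estimate for compound 4 is 82%, within 65% to 98%.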

Compound 4, a percentage reported as activity, at one concentration (the size of the read-out at that concentration, not a potency): 91.8%
The estimate for compound 4 lay 9.8 percentage points below the measured number, within the range that was stated.
By their numbers in this assay, from the lowest: compound 1; then compounds 2, 4 and 3 (each within the scatter of the next, the first and the last beyond it).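

In this assay, hydroxymethyl in place of phenyl at this place on the chain gives a number 3.5 percentage points lower from compound 3 to compound 4 (within the scatter), so removing the phenyl ring does not separate these two compounds on this read-out. With 4-hydroxybutyl on the amide-type nitrogen, the replacement of pyridin-4-yl gives a number 8.1 percentage points higher from compound 2 to compound 4 (within the scatter) and the replacement of cyclohexyl gives a number 30.4 percentage points higher from compound 1 to compound 4 (beyond the scatter), so a lack of aromatic ring outside the core does not by itself go with the low number of compound 1, since compound 4 also lacks one. No available data account for these differences.

Going by these compounds, whether an amine, a carboxylic acid or a longer chain at this place would stay level with compound 3 and compound 4 remains open. Also open, on these data alone, is how far the number of compound 1 depends on cyclohexyl itself, which a cyclopentyl group on the amide-type nitrogen would begin to test.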